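Benzyl ether variation in the acylthiourea series

The compounds below may be only part of what the source reports. "The series", "measured", "known", "first", "only" and "open" are said of these compounds alone.

Compound 3 `Cc1ccc(NC(=S)NC(=O)c2ccc(OCc3cccc(F)c3)cc2)cc1-c1nc2ccccc2[nH]1` gives 55300 nM in a functional assay on HT-29 cells (Homo sapiens) for inhibition, read by MTT assay, with a stated time of 48 h; on this read-out lower numbers stand for stronger inhibition and higher numbers for weaker inhibition. Among the three measured compounds it stands second highest: compound 2 `Cc1ccc(NC(=S)NC(=O)c2ccc(OCc3cccc(Cl)c3Cl)cc2)cc1-c1nc2ccccc2[nH]1` gives 63700 nM, and compound 1 `Cc1ccc(NC(=S)NC(=O)c2ccc(OCc3ccc(C(F)(F)F)cc3)cc2)cc1-c1nc2ccccc2[nH]1` gives 17600 nM. The steps of a 3.1-fold higher number from compound 1 to compound 3 (0.50 log units; beyond the scatter) and a 1.2-fold lower number from compound 2 to compound 3 (0.06 log units; within the scatter) frame where compound 3 sits. Compound 4 `Cc1ccc(NC(=S)NC(=O)c2ccc(OCc3ccccc3Cl)cc2)cc1-c1nc2ccccc2[nH]1` differs from compound 3 by 2-chlorophenyl in place of 3-fluorophenyl on a saturated chain carbon bound to an oxygen on an aromatic ring. Among the compounds with values here, the step that bears most directly on this is a 1.2-fold lower number from compound 2 to compound 3 (0.06 log units; within the scatter), which exchanged a chlorine-bearing ring for the 3-fluorophenyl without passing the scatter; the step of a 3.1-fold higher number from compound 1 to compound 3 (0.50 log units; beyond the scatter) shows the only change here that did. Neither step involves the 2-chlorophenyl itself, so the expected step of a 1.0-fold lower number from compound 3 to compound 4 (0.00 log units; within the scatter) is none beyond the scatter. Compound 4 is therefore estimated at 55000 nM, in the range 20000 nM to 150000 nM.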

Compound 4, half-maximal inhibitory concentration: 23700 nM
Estimate against measurement, compound 4: 2.3-fold (0.37 log units) above, and the stated range covers the measured number.
By their numbers in this assay, from the lowest: compounds 1 and 4 (each within the scatter of the next); then compounds 3 and 2 (each within the scatter of the next).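

The substituent pattern on this ring matters even among chlorine-bearing rings: a 2.7-fold lower number from compound 2 to compound 4 (0.43 log units; beyond the scatter) comes with hydrogen in place of chloro on an aromatic carbon, and a 2.3-fold lower number from compound 3 to compound 4 (0.37 log units; beyond the scatter) separates 2-chlorophenyl from 3-fluorophenyl. With a 1.3-fold higher number from compound 1 to compound 4 (0.13 log units; within the scatter), 2-chlorophenyl and 4-(trifluoromethyl)phenyl cannot be told apart, so a low number here is not tied to one kind of substituent. No evidence on hand bears on the reason for these steps.

Still open, on these data alone, is where unsubstituted phenyl would fall, and whether a ring carrying an amine or a carboxylic acid would keep the lower numbers of compound 1 and compound 4.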